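Extending a side chain by one carbon in a purine series

This account rests on a few compounds, and the source may have more. Where it says the series, first, only, none or still open, it means among the compounds named here.

Three compounds share a core and differ only in the side chain on the amide-linked carbon. Compound 1 `O=C(CN(c1nc(Cl)nc2[nH]cnc12)C1CC1)N[C@@H](CO)C(=O)OCc1ccccc1` gives 31.9% in a functional assay on the whole organism (Tail, strain ICR) with Mus musculus as the target, in the tail flick test, with a stated time of 30 min, at a dose of 25 umol/kg by the oral route (on this read-out higher numbers stand for a stronger effect at the one dose given and lower numbers for a weaker effect), compound 2 `CC(C)[C@H](NC(=O)CN(c1nc(Cl)nc2[nH]cnc12)C1CC1)C(=O)OCc1ccccc1` gives 33.4%, and compound 3 `O=C(CN(c1nc(Cl)nc2[nH]cnc12)C1CC1)N[C@@H](CC(=O)OCc1ccccc1)C(=O)OCc1ccccc1` gives 34.7%, the highest of the three numbers, though every gap between them lies within the scatter. Compound 4 `O=C(CN(c1nc(Cl)nc2[nH]cnc12)C1CC1)N[C@@H](CCC(=O)OCc1ccccc1)C(=O)OCc1ccccc1` carries the change ((benzyloxycarbonyl)methyl in place of benzyloxycarbonyl on a saturated chain carbon, two bonds along the chain from an amide-type nitrogen and a carbonyl carbon). Going by the values given here, the steps that bear on this place, a number 2.8 percentage points higher from compound 1 to compound 3 (within the scatter) and a number 1.3 percentage points higher from compound 2 to compound 3 (within the scatter), together with a number 1.5 percentage points higher from compound 1 to compound 2 (within the scatter), were all within the scatter, so no shift beyond the scatter is expected here. The expected step is a number 0.7 percentage points lower from compound 3 to compound 4 (within the scatter). Compound 4 is therefore estimated at 34%, within a range from 26% to 42%.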

Compound 4, a percentage reported as activity, at one dose (the size of the read-out at that dose, not a potency): 52.8%
Beside the measured number, compound 4's estimate is 18.8 percentage points below it; the whole stated range lies below it.
By their numbers in this assay, from the lowest: compounds 1, 2 and 3 (each within the scatter of the next); then compound 4.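

In this assay the earlier changes at this place stayed within the scatter, but (benzyloxycarbonyl)methyl in place of benzyloxycarbonyl gives a number 18.1 percentage points higher from compound 3 to compound 4 (beyond the scatter) and so shows that this place can respond to a change. The same side chain also stands clear of the other two, with a number 19.4 percentage points higher from compound 2 to compound 4 (beyond the scatter) and a number 20.9 percentage points higher from compound 1 to compound 4 (beyond the scatter), so compound 4 is the most active of the four at this dose. Nothing shown here explains this gain.

As far as these compounds go, whether a longer chain would raise the number further remains open. So does the effect of a carboxylic acid or an amine at the end of the chain in place of the benzyl ester.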